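The source may report more compounds than this note shows. Statements on the series, on what has been measured and on what is new or still open speak of the compounds shown alone.

Compound 1 `C=CCN(C)C(=O)c1ccc(C(CC)(CC)c2ccc(OCCC(O)(CC)CC)c(C)c2)n1CC` is the starting point of this comparison. In a functional assay on MCF7 cells (Homo sapiens) for antiproliferative activity, read by MTT assay, with a stated time of 48 h (on this read-out higher numbers stand for weaker inhibition and lower numbers for stronger inhibition), compound 1 gives > 50000 nM, which is a limit of the assay rather than a number, so compound 1 stands at the weakest end of what has been measured here (the limit of > 50000 nM in this assay, at which 2 of the 3 values shown sit). Compound 2 `C#CC(C)OC(=O)c1ccc(C(CC)(CC)c2ccc(OCCC(O)(CC)CC)c(C)c2)n1CC` in this assay gives > 50000 nM, again a limit and not a number. Compound 3 `CCC(C)C(NC(=O)c1ccc(C(CC)(CC)c2ccc(OCCC(O)(CC)CC)c(C)c2)n1CC)C(=O)O` in this assay gives 11300 nM.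

Compound 4 `CCn1c(C(=O)NC(C)C(=O)O)ccc1C(CC)(CC)c1ccc(OCCC(O)(CC)CC)c(C)c1` differs from compound 1 in one place: (1-carboxyethyl)amino in place of allyl(methyl)amino on a carbonyl carbon. The step that bears on this change most directly is an at least 4.4-fold lower number from compound 1 to compound 3 (0.64 log units; beyond the scatter), where an amino acid carrying a free carboxylic acid also replaced the allyl(methyl)amino group on the carbonyl carbon. The step of an at least 4.4-fold lower number from compound 2 to compound 3 (0.64 log units; beyond the scatter) points the same way. Among the measured compounds shown here, a step in the same direction is therefore expected for compound 4, kept modest because compound 3 gives 11300 nM with an entering group that is not the same as the one entering in compound 4. For compound 4 the expected value in this assay is 15000 nM, with a range from 5000 nM to 50000 nM. The step from compound 1 to compound 4 is thus expected to be an at least 3.3-fold lower number from compound 1 to compound 4 (0.52 log units; beyond the scatter).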

Compound 4, half-maximal inhibitory concentration: 19700 nM
For compound 4 the middle estimate is 1.3-fold (0.12 log units) below the measured one; the range from low to high includes it.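

In this assay, a second amino acid with a free carboxylic acid on the carbonyl carbon also gives a readable value, with an at least 2.5-fold lower number from compound 1 to compound 4 (0.40 log units; beyond the scatter) and an at least 2.5-fold lower number from compound 2 to compound 4 (0.40 log units; beyond the scatter), so the effect seen with compound 3 does not depend on its sec-butyl group. With methyl in place of sec-butyl on the chain carbon, the result is a 1.7-fold higher number from compound 3 to compound 4 (0.24 log units; within the scatter), so this assay does not separate these two amino acid amides. Compounds 1 and 2 each stand at a limit, so the steps from them give only a minimum size: the limit of > 50000 nM in this assay, at which 2 of the 4 values shown sit.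

What the compounds shown leave open is whether the free carboxylic acid itself is needed, a question that the methyl ester of the same amino acid would address. Also open, on these data alone, is how a larger group on that chain carbon, such as benzyl, would read out.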